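The source may hold more compounds than are shown below. What is called first, only, known or untested is meant among the compounds shown, and "the series" means these compounds.

Compound 1 `COc1ccccc1-c1nnc(-c2ccc(C(=O)N/N=C/c3cc(O)ccc3O)cc2)o1` gives 100000 nM in an ADME assay on THP-1 cells (Homo sapiens) for cytotoxicity; on this read-out lower numbers stand for stronger inhibition and higher numbers for weaker inhibition.
Compound 2 `COc1ccccc1-c1nnc(-c2ccc(C(=O)N/N=C/c3ccc(F)cc3)cc2)o1` gives 427000 nM in this assay.
Compound 3 `COc1ccc(O)c(/C=N/NC(=O)c2ccc(-c3nnc(-c4ccccc4OC)o3)cc2)c1` gives 303000 nM in this assay.

Compound 3 holds the second highest of the three numbers. Its nearest neighbour is compound 2, and the gap between them, a 1.4-fold lower number from compound 2 to compound 3 (0.15 log units; within the scatter), lies within the scatter. Its furthest neighbour is compound 1, and that gap, a 3.0-fold higher number from compound 1 to compound 3 (0.48 log units; beyond the scatter), is a modest step beyond the scatter.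

Compound 4 `COc1ccccc1-c1nnc(-c2ccc(C(=O)N/N=C/c3ccc(O)cc3)cc2)o1` has not yet been measured. It differs from compound 3 in one place: 4-hydroxyphenyl in place of 2-hydroxy-5-methoxyphenyl on a carbon with a double bond to nitrogen.

Two measured steps change the same aryl group on the carbon with a double bond to nitrogen. The step of a 4.3-fold higher number from compound 1 to compound 2 (0.63 log units; beyond the scatter) is modest and beyond the scatter, while the step of a 1.4-fold lower number from compound 2 to compound 3 (0.15 log units; within the scatter) stays within the scatter. The three compounds thus span only a narrow band, and the 4-hydroxyphenyl group of compound 4 shares a single ring substituent with the 4-fluorophenyl group of compound 2 and the hydroxy group with compound 1. The expected step in this assay from compound 3 to compound 4 is therefore a 1.2-fold lower number from compound 3 to compound 4 (0.08 log units; within the scatter), no step beyond the scatter. Compound 4 is expected to give 250000 nM, with a range from 100000 nM to 600000 nM.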

Compound 4, half-maximal inhibitory concentration: 261000 nM
Compound 4: middle estimate off by 1.0-fold (0.02 log units), on the low side; low and high end bracket the measured number.
By their numbers in this assay, from the lowest: compound 1; then compounds 4, 3 and 2 (each within the scatter of the next).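

In this assay the 4-hydroxyphenyl group on the carbon with a double bond to nitrogen leaves compound 4 within the scatter of two differently substituted neighbours: a 1.2-fold lower number from compound 3 to compound 4 (0.06 log units; within the scatter) arises from replacing 2-hydroxy-5-methoxyphenyl, and a 1.6-fold lower number from compound 2 to compound 4 (0.21 log units; within the scatter) arises from hydroxy in place of fluoro on an aromatic carbon. Compound 1, with its 2,5-dihydroxyphenyl group, now stands apart from three compounds rather than two, and a 2.6-fold higher number from compound 1 to compound 4 (0.42 log units; beyond the scatter) is a modest step beyond the scatter, so the aryl groups of compound 2, compound 3 and compound 4 read alike at this place and compound 1 alone goes against that pattern. No measurement shown here offers an explanation for the separate place of compound 1.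

Going by these compounds, it remains open whether the lower number of compound 1 is confined to the 2,5-dihydroxyphenyl group or would also appear with a phenyl ring carrying an amine or a carboxylic acid at this place. Also open, on these data alone, is whether a longer chain in place of the aromatic ring would stay in the same band as compound 2, compound 3 and compound 4.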